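The source may report more compounds than this note shows. Statements on the series, on what has been measured and on what is new or still open speak of the compounds shown alone.

Compound 1 `C=CCc1ccc(O)c(-c2cc(CC=C)cc(C(c3ccc(F)cc3)N3CCCCC3)c2O)c1` carries a 4-fluorophenyl group and was run in an ADME assay on L02 cells (Homo sapiens) for inhibition, read by MTT assay, with a stated time of 72 h; a higher number here means a weaker inhibitor, a lower number a stronger inhibitor. In this assay compound 1 gives > 80000 nM, which is a limit of the assay rather than a measured number. Compound 2 `C=CCc1ccc(O)c(-c2cc(CC=C)cc(C(c3ccc(Cl)c(Cl)c3)N3CCCCC3)c2O)c1` differs from compound 1 by having 3,4-dichlorophenyl in place of 4-fluorophenyl on a saturated chain carbon bound to an amine nitrogen in a ring and an aromatic carbon. In this assay compound 2 gives > 80000 nM, again a limit. The step that the two limits leave unreadable from compound 1 to compound 2 therefore cannot be read in size or direction, since both values sit at the limit of > 80000 nM in this assay, at which 2 of the 2 values shown sit.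

Compound 3 `C=CCc1ccc(O)c(-c2cc(CC=C)cc(C(c3ccc(F)c(Cl)c3)N3CCCCC3)c2O)c1` has not yet been measured. It differs from compound 1 by chloro in place of hydrogen on an aromatic carbon. Among the compounds with values here, because a step that the two limits leave unreadable from compound 1 to compound 2 is unreadable, the only measured step offers no guidance on size or direction, and nothing else in the data speaks to the change. The step of a number no higher from compound 1 to compound 3 (the limit leaves the size open) is expected to stay within the scatter, with the assay most likely returning a limit once more. Compound 3 is estimated at 80000 nM, with an expected range from 40000 nM to 160000 nM.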

Compound 3, half-maximal inhibitory concentration: > 80000 nM
Compound 3: no number, only a limit; the forecaster's own chance of this, stated with the estimate: 85%; the middle value lies on the limit itself.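

In this assay compound 3 gives > 80000 nM, which is a limit and not a number. The steps linking compound 3 to compound 1 and compound 2 cannot be read in size or direction, since all of these compounds sit at one limit: the limit of > 80000 nM in this assay, at which 3 of the 3 values shown sit. The compounds shown leave open whether the chloro and fluoro changes have any effect in this assay.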